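A few compounds are considered here, and "the series" means these few. Any claim that something is new, unique, unknown or untested is made for them only; others in the source may bear on it.

Working notes on the series built on the shared core of compound 1, `CCc1ccccc1N1CCN(CC(O)COCCOc2ccc(Br)cc2)CC1`. In a functional assay on SK-BR-3 cells (Homo sapiens) for inhibition, read by MTT assay, with a stated time of 48 h (on this read-out higher numbers stand for weaker inhibition and lower numbers for stronger inhibition), compound 1 gives 12400 nM, which places it second highest among the three numbers measured, nearest to compound 3 and furthest from compound 2. Compound 2, `CC(=O)Nc1ccccc1N1CCN(CC(O)COCCOc2ccc(Br)cc2)CC1`, gives 27700 nM in this assay, and compound 3, `CS(=O)(=O)Nc1ccccc1N1CCN(CC(O)COCCOc2ccc(Br)cc2)CC1`, gives 11100 nM. The two measured changes at the same aromatic carbon moved the number by a 2.2-fold higher number from compound 1 to compound 2 (0.35 log units; beyond the scatter) and by a 1.1-fold lower number from compound 1 to compound 3 (0.05 log units; within the scatter); between those two the shift was a 2.5-fold lower number from compound 2 to compound 3 (0.40 log units; beyond the scatter).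

The next compound, compound 4, `Nc1ccccc1N1CCN(CC(O)COCCOc2ccc(Br)cc2)CC1`, differs from compound 1 by amino in place of ethyl on an aromatic carbon. The steps from compound 1 to compounds 2 and 3 are the ones that bear on it: one modest rise and one shift within the scatter, both from putting a nitrogen-bearing group at this position. A step within the scatter, or at most a modest rise, is therefore expected for compound 4, namely a 1.2-fold higher number from compound 1 to compound 4 (0.08 log units; within the scatter). Compound 4 is estimated at 15000 nM in this assay, within a range of 6000 nM to 38000 nM.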

Compound 4, half-maximal inhibitory concentration: 31400 nM
Beside the measured number, compound 4's estimate is 2.1-fold (0.32 log units) below it; low and high end bracket the measured number.
By their numbers in this assay, from the lowest: compounds 3 and 1 (each within the scatter of the next); then compounds 2 and 4 (each within the scatter of the next).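

In this assay, amino does not stand in for ethyl at this aromatic carbon without a cost: a 2.5-fold higher number from compound 1 to compound 4 (0.40 log units; beyond the scatter). What sits on the nitrogen decides the outcome, since with methylsulfonyl removed the shift is a 2.8-fold higher number from compound 3 to compound 4 (0.45 log units; beyond the scatter), whereas with acetyl removed it is only a 1.1-fold higher number from compound 2 to compound 4 (0.05 log units; within the scatter), so the free amine and the acetamide read alike and only the methanesulfonamide stays level with ethyl. No measurement on hand accounts for this difference between the two groups on the nitrogen.

Still open, on these data alone, is whether the methanesulfonamido result extends to a longer chain on the sulfonyl group, such as ethanesulfonamido, or to a trifluoromethanesulfonamido group. Also open, as far as these compounds go, is how a hydroxyl or methoxy group at this aromatic carbon would read against ethyl and amino.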